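Formyl to acetyl on the heteroaryl ketone: working note

This account rests on a few compounds, and the source may have more. Where it says the series, first, only, none or still open, it means among the compounds named here.

compound 1 `O=C(CCCCCCc1ccccc1)c1nc(Br)co1`: 3 nM in an assay on isolated protein for inhibition of Fatty-acid amide hydrolase 1 (Rattus norvegicus); on this read-out lower numbers stand for stronger inhibition and higher numbers for weaker inhibition
compound 2 `O=Cc1coc(C(=O)CCCCCCc2ccccc2)n1`: 55 nM in this assay

Among the compounds with values here, compound 2 stands at the higher of the two numbers so far in this assay; the gap to the other measured compound is the single step recorded, an 18-fold higher number from compound 1 to compound 2 (1.26 log units; beyond the scatter), which is a large one and well beyond the scatter.

Compound 3 `CC(=O)c1coc(C(=O)CCCCCCc2ccccc2)n1` is the next point: it differs from compound 2 by methyl in place of hydrogen on a carbonyl carbon. Within the data shown here, no measured pair touches this carbonyl substituent. Among the measured compounds shown here, the one recorded step, an 18-fold higher number from compound 1 to compound 2 (1.26 log units; beyond the scatter), exchanges the whole group on the aromatic carbon rather than extending a group that is already there, so it bears on the present change only loosely, as a sign that this part of the molecule matters to this assay. With nothing closer to lean on, the working expectation is a modest rise in the number, within or at the edge of the scatter, rather than a second large shift.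

For compound 3 the estimate in this assay is 90 nM, with a range of 25 nM to 320 nM. The expected step is a 1.6-fold higher number from compound 2 to compound 3 (0.21 log units; within the scatter).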

Compound 3, inhibition constant: 2 nM
Estimate against measurement, compound 3: 45-fold (1.65 log units) above, outside the stated range (below it).
By their numbers in this assay, from the lowest: compounds 3 and 1 (each within the scatter of the next); then compound 2.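

Within this assay, the step from formyl to acetyl is a 28-fold lower number from compound 2 to compound 3 (1.44 log units; beyond the scatter) and is large, so this position responds sharply to a methyl in place of hydrogen on a carbonyl carbon, a change of a single heavy atom, whereas the earlier step only showed that exchanging the whole group matters. Within the data shown here, the second new step, a 1.5-fold lower number from compound 1 to compound 3 (0.18 log units; within the scatter), shows that acetyl and bromo on the aromatic carbon cannot be told apart in this assay, which leaves compound 2 alone at the high end of the three and makes the formyl group, not the bromo group, the exception so far. Nothing available explains why the hydrogen on this carbonyl carbon goes with such a large step.

Still open, from the compounds shown here alone, is whether any carbonyl substituent other than hydrogen keeps the low number, or whether the effect is specific to methyl; an ethyl group, a trifluoromethyl group or an amine on the same carbonyl carbon would separate these readings. Going by these compounds, it is also open whether the size of this step carries over to a shorter chain in place of the phenyl-bearing chain on the shared core.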